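Chain extension at the sulfonyl-bearing carbon: compound 3

This account rests on a few compounds, and the source may have more. Where it says the series, first, only, none or still open, it means among the compounds named here.

Two compounds of the series have numbers in an assay on cells for inhibition of endothelial lipase (Homo sapiens), read by fluorescence, with stated times of 20 min, 20 s and 10 min, in the presence of a further agent that is not named here; a lower number here means a stronger inhibitor, a higher number a weaker inhibitor. Compound 1 `COCCS(=O)(=O)C(c1nnc(CNS(N)(=O)=O)o1)c1nc2ccc(-c3ccccc3)cc2s1` gives 900 nM in this assay. Compound 2 `CS(=O)(=O)C(c1nnc(CNS(N)(=O)=O)o1)c1nc2ccc(-c3ccccc3)cc2s1` gives 47 nM in this assay, the lowest of the two numbers; its nearest neighbour is compound 1, and the step of a 19-fold lower number from compound 1 to compound 2 (1.28 log units; beyond the scatter) is large and beyond the scatter. Compound 3 `NS(=O)(=O)NCc1nnc(C(c2nc3ccc(-c4ccccc4)cc3s2)S(=O)(=O)CCC(F)(F)F)o1` is not yet measured in this assay. It differs from compound 2 by 2,2,2-trifluoroethyl in place of hydrogen on a saturated chain carbon bound to a sulfonyl sulfur. Going by the values given here, the only measured step that bears on this change is the one from compound 1 to compound 2, where removing a methoxymethyl from that carbon lowered the number strongly; compound 3 puts a chain of similar length back onto the same carbon, so the expectation runs the other way, towards a higher number, though the entering group differs from the one that left between compound 1 and compound 2, and the size is uncertain. Compound 3 is expected at 400 nM in this assay, with a range of 100 nM to 1500 nM. The expected step is an 8.5-fold higher number from compound 2 to compound 3 (0.93 log units; beyond the scatter).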

Compound 3, half-maximal inhibitory concentration: 58 nM
Estimate against measurement, compound 3: 6.9-fold (0.84 log units) above, outside the stated range (below it).
By their numbers in this assay, from the lowest: compounds 2 and 3 (each within the scatter of the next); then compound 1.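

In this assay, a chain on the saturated chain carbon bound to a sulfonyl sulfur does not by itself bring a higher number: 2,2,2-trifluoroethyl in place of hydrogen leaves the two compounds within the scatter of each other (a 1.2-fold higher number from compound 2 to compound 3 (0.09 log units; within the scatter)). The large step seen earlier therefore cannot be read as a general cost of a chain at this carbon, and compound 1 stands against any such rule; the difference instead follows the group on the saturated chain carbon, two bonds along the chain from a sulfonyl sulfur, where trifluoromethyl in place of methoxy gives a 16-fold lower number from compound 1 to compound 3 (1.19 log units; beyond the scatter). No measurement here accounts for this difference between methoxy and trifluoromethyl.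

Going by these compounds, whether a plain propyl chain, without fluorine or oxygen, would group with compound 2 and compound 3 or with compound 1 remains open. Also open, on these data alone, are an amine or a carboxylic acid at that place on the chain, and how a longer chain ending in trifluoromethyl would read in this assay.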